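The compounds below may be only part of what the source reports. "The series", "measured", "known", "first", "only" and "open" are said of these compounds alone.

Compound 1 `Nc1nccc(Nc2ccc(Oc3ccc(Cl)cc3)cc2)n1`: 41 mL.min-1.g-1
Compound 2 `Nc1cccc(Nc2ccc(Oc3ccc(Cl)cc3)cc2)n1`: 238 mL.min-1.g-1
Compound 3 `Nc1cc(Nc2ccc(Oc3ccc(Cl)cc3)cc2)cnn1`: > 399 mL.min-1.g-1 (a limit of the assay)

These three compounds share one core and differ only in the amino-bearing ring that sits on a nitrogen on an aromatic ring. In an in vitro ADME assay on microsomes from liver (Rattus norvegicus) for metabolic stability (on this read-out lower numbers stand for slow clearance and higher numbers for fast clearance), compound 1 gives 41 mL.min-1.g-1, the lowest of the two plain numbers shown. Compound 2 gives 238 mL.min-1.g-1. Compound 3 reaches only a limit of this assay, > 399 mL.min-1.g-1, as the data note (the limit of > 399 mL.min-1.g-1 in this assay, at which 1 of the 3 values shown sits); its true number is not known.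

Compound 4 `Nc1cnnc(Nc2ccc(Oc3ccc(Cl)cc3)cc2)c1` has not yet been measured. It differs from compound 1 in one place: 5-aminopyridazin-3-yl in place of 2-aminopyrimidin-4-yl on a nitrogen on an aromatic ring. Among the measured compounds shown here, two measured steps bear on this change, both leaving the same 2-aminopyrimidin-4-yl group of compound 1: a 5.8-fold higher number from compound 1 to compound 2 (0.76 log units; beyond the scatter) and an at least 9.7-fold higher number from compound 1 to compound 3 (0.98 log units; beyond the scatter). Each replacement of that group raised the number clearly beyond the scatter, so a step upward of similar size is expected here: a 5.6-fold higher number from compound 1 to compound 4 (0.75 log units; beyond the scatter). Compound 4 is therefore estimated at 230 mL.min-1.g-1 in this assay, with a likely range from 90 mL.min-1.g-1 to 399 mL.min-1.g-1, and a real chance that only a limit is reported.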

Compound 4, intrinsic clearance in microsomes: > 399 mL.min-1.g-1
Compound 4: a limit, no number; the forecaster's own chance of this, stated with the estimate: 30%; middle value at least 1.7-fold (0.23 log units) away from the limit.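

The 5-aminopyridazin-3-yl group has the same counts of heavy atoms, hydrogen-bond donors and acceptors as the 2-aminopyrimidin-4-yl group, yet the change gives an at least 9.7-fold higher number from compound 1 to compound 4 (0.98 log units; beyond the scatter), so among the compounds shown those counts alone do not set the number, and all three replacements of the 2-aminopyrimidin-4-yl group raise it. Against the 6-aminopyridin-2-yl group the result is an at least 1.6-fold higher number from compound 2 to compound 4 (0.22 log units; that floor lies within the scatter), so that pair cannot be put in order. Compound 4 stands at a limit in this assay, and the step from compound 3 cannot be read since both compounds sit at a limit: the limit of > 399 mL.min-1.g-1 in this assay, at which 2 of the 4 values shown sit.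

Going by these compounds, the true order of compound 3 and compound 4 remains open. So does whether the low number of compound 1 would hold if a methyl group or a hydroxyl group replaced the amine on its ring.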